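Methyl step from compound 3 to compound 4

This account rests on a few compounds, and the source may have more. Where it says the series, first, only, none or still open, it means among the compounds named here.

Values in a functional assay on P388 cells (Mus musculus) for cytotoxicity; a lower number here means a stronger inhibitor, a higher number a weaker inhibitor:
- compound 1 `CC(C)=CCCC1=CCc2c(O)ccc(O)c2C1`: 2100 nM
- compound 2 `CC(C)=CCCC1=CCc2c(O)cc(C)c(O)c2C1`: 3800 nM
- compound 3 `CC(C)=CCCC1=CCC2=C(C1)C(=O)C=CC2=O`: 1000 nM
- compound 4 `CC(C)=CCCC1=CCC2=C(C1)C(=O)C(C)=CC2=O`: not yet measured

Compound 3 has the lowest number of the three measured compounds in this assay, and its gaps to both compound 1 and compound 2 lie beyond the scatter. Compound 4 differs from it at one place: methyl in place of hydrogen on a double-bonded ring carbon.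

Going by the values given here, one measured step bears on this change: a 1.8-fold higher number from compound 1 to compound 2 (0.26 log units; within the scatter). That step is also a methyl in place of hydrogen, but on an aromatic carbon, so it is a related case and not the same one. It lies within the scatter, and this single example gives no firm direction. No step beyond the scatter is therefore expected in this assay, with at most a slight drift towards a higher number.

For compound 4 the estimated value is 1400 nM, with an expected range of 600 nM to 3200 nM. This estimate corresponds to an expected 1.4-fold higher number from compound 3 to compound 4 (0.15 log units; within the scatter).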

Compound 4, half-maximal inhibitory concentration: 3900 nM
Compound 4: middle estimate off by 2.8-fold (0.44 log units), on the low side, and the stated range ends below it.
By their numbers in this assay, from the lowest: compound 3; then compounds 1, 2 and 4 (each within the scatter of the next).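

In this assay, going by these compounds alone, methyl in place of hydrogen on this double-bonded ring carbon gives a 3.9-fold higher number from compound 3 to compound 4 (0.59 log units; beyond the scatter) and so moves the number towards weaker inhibition, the first methyl change to do so beyond the scatter. Within the data shown here, the only earlier methyl step, on an aromatic carbon, gave a 1.8-fold higher number from compound 1 to compound 2 (0.26 log units; within the scatter) and stays within the scatter, so the two methyl changes do not read alike in this small set. No measurement is available that explains the step at this carbon.

The compounds shown leave open whether the loss is specific to methyl or would also follow an ethyl group, a longer chain, a methoxy group or an amine on the same carbon. A single step from one pair also leaves open whether the same methyl change would act similarly on the other double-bonded ring carbon.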